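The source may report more compounds than this note shows. Statements on the series, on what has been measured and on what is new or still open speak of the compounds shown alone.

Measured so far in an in vitro ADME assay on microsomes (Homo sapiens) for metabolic stability; a higher number here means that the compound lasts longer, a lower number that the compound disappears faster:
compound 1 `CCc1nc(NC(CC)CC)c(OC)nc1-c1ccc(OC)cc1C(F)(F)F`: 2 h
compound 2 `CCc1nc(-c2ccc(OC)cc2C(F)(F)F)c(CC)nc1NC(CC)CC`: 0.2 h
compound 3 `CCc1nc(-c2ccc(OC(F)(F)F)cc2OC)c(CC)nc1NC(CC)CC`: 0.217 h

Compound 2 has the lowest number of the three. Within the data shown here, compound 3 lies within the scatter of it; compound 1 lies beyond the scatter, the only single-point step in the set being a 10-fold lower number from compound 1 to compound 2 (1.00 log units; beyond the scatter). Compound 4 `CCc1nc(-c2ccc(OC)cc2O)c(CC)nc1NC(CC)CC` is not yet measured and differs from compound 2 by hydroxy in place of trifluoromethyl on an aromatic carbon. Among the measured compounds shown here, no measured step touches this group: the one known step, a 10-fold lower number from compound 1 to compound 2 (1.00 log units; beyond the scatter), concerns a different group on the shared core, and compound 3 against compound 2 is not a single change and shows values within the scatter of each other. With nothing bearing on the change, no step beyond the scatter is expected, a 1.3-fold higher number from compound 2 to compound 4 (0.10 log units; within the scatter). Compound 4 is therefore estimated at 0.25 h, between 0.1 h and 0.6 h.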

Compound 4, half-life: 0.3 h
Beside the measured number, compound 4's estimate is 1.2-fold (0.08 log units) below it; low and high end bracket the measured number.
By their numbers in this assay, from the lowest: compounds 2, 3 and 4 (each within the scatter of the next); then compound 1.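

In this assay, the step at this place on the aromatic ring, a 1.5-fold higher number from compound 2 to compound 4 (0.18 log units; within the scatter), stays within the scatter, so replacing trifluoromethyl with hydroxy, which adds a hydrogen-bond donor, does not separate the two compounds. Among these compounds, the only step beyond the scatter remains a 10-fold lower number from compound 1 to compound 2 (1.00 log units; beyond the scatter), at a different place on the shared core. No evidence at hand bears on this result.

Going by these compounds, whether an amine or a methyl group at this place would also stay within the scatter remains open. So does whether hydroxy would behave the same way with methoxy on the core, as in compound 1.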